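Replacing the methoxycarbonyl group on the ring amine of compound 3

The source may report more compounds than this note shows. Statements on the series, on what has been measured and on what is new or still open speak of the compounds shown alone.

Three compounds of the series have numbers in a functional assay on CHO-K1 cells with Glucose-dependent insulinotropic receptor (Homo sapiens) as the target, read by a luciferase reporter, with a stated time of 5 h; on this read-out lower numbers stand for smaller maximal responses and higher numbers for larger maximal responses. Compound 1 `CC(C)OC(=O)N1CCC(Oc2cccc3c2CCN3c2ccc(S(C)(=O)=O)cc2F)CC1` gives 62%. Compound 2 `CC(C)OC(=O)N1CCC(Oc2ncnc3c2CCN3c2ccc(C#N)cc2F)CC1` gives 134%. Compound 3 `COC(=O)N1CCC(Oc2ncnc3c2CCN3c2ccc(S(C)(=O)=O)cc2F)CC1` gives 119%, which is the second highest of the three: compound 2 lies above it beyond the scatter, and compound 1 lies below it, also beyond the scatter. Among the compounds with values here, no pair among the three differs in a single place, so none of these gaps can be tied to one structural change.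

Compound 4 `CS(=O)(=O)c1ccc(N2CCc3c(OC4CCN(C(=S)Sc5ccccc5)CC4)ncnc32)c(F)c1` is not yet measured in this assay. Against compound 3 the difference is a group of 9 heavy atoms (7 carbon, 2 sulfur; one six-membered aromatic ring of carbon only) in place of a group of 4 heavy atoms (2 carbon, 2 oxygen; no ring), on an amine nitrogen in a ring. Within the data shown here, the series holds no precedent for this kind of exchange on the ring amine, so the size of the step is open. The expectation is a modest downward step from compound 3 to compound 4 of a number 19 percentage points lower from compound 3 to compound 4 (beyond the scatter), near the edge of the scatter. For compound 4 the estimate in this assay is 100%, within a range from 60% to 140%.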

Compound 4, largest response reached (reported as percent of maximum), in percent of the reference or control that the assay uses: 103%
Compound 4: the middle estimate sits 3 percentage points below what was measured; low and high end bracket the measured number.
By their numbers in this assay, from the lowest: compound 1; then compound 4; then compound 3; then compound 2.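

Within the data shown here, compound 3 to compound 4 is the first single-place step, and it gives the ring amine its first reading in this assay: a number 16 percentage points lower from compound 3 to compound 4 (beyond the scatter). Methoxycarbonyl can therefore give way to the entering group of 9 heavy atoms, with its six-membered aromatic ring of carbon only, at a real but modest cost, and compound 4 keeps a substantial maximal response at 103%. Nothing measured here accounts for the size of this step.

Still open, from the compounds shown here alone, is whether the step follows the aromatic ring or the two sulfur atoms of the entering group, a separation that a phenoxycarbonyl group on the same nitrogen would allow. Going by these compounds, the reading of that nitrogen with a plain benzyl group or an acetyl group also remains open.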